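A propyl amide follows the weakest of three amides

A few compounds are considered here, and "the series" means these few. Any claim that something is new, unique, unknown or untested is made for them only; others in the source may bear on it.

Compound 1 `O=C(Nc1cccc(-c2oc3cc(-c4ccc(F)cc4)ccc3c(=O)c2O)c1)c1ccc(F)cc1` gives 5350 nM in a functional assay on HeLa cells (Homo sapiens) for antiproliferative activity, read by CCK-8 assay, with a stated time of 72 h; a lower number here means a stronger inhibitor, a higher number a weaker inhibitor. Compound 2 `Cc1cccc(C(=O)Nc2cccc(-c3oc4cc(-c5ccc(F)cc5)ccc4c(=O)c3O)c2)c1` gives 6650 nM in this assay, and the change a 1.2-fold higher number from compound 1 to compound 2 (0.09 log units; within the scatter) does not separate the two. Compound 3 `Cc1cc(C(=O)Nc2cccc(-c3oc4cc(-c5ccc(F)cc5)ccc4c(=O)c3O)c2)ccc1F` gives 18900 nM in this assay, the highest number among the three, with a 3.5-fold higher number from compound 1 to compound 3 (0.55 log units; beyond the scatter) and a 2.8-fold higher number from compound 2 to compound 3 (0.45 log units; beyond the scatter) both beyond the scatter. The step to compound 4 `CCCc1ccc(C(=O)Nc2cccc(-c3oc4cc(-c5ccc(F)cc5)ccc4c(=O)c3O)c2)cc1` is 4-propylphenyl in place of 4-fluoro-3-methylphenyl on a carbonyl carbon. The two measured steps that bear on it are the additions that led to compound 3: the methyl added from compound 1 to compound 3 and the fluoro added from compound 2 to compound 3 each raised the number modestly, so their removal would be expected to undo that rise. The 4-propylphenyl itself has no measured precedent here, and no sign of its effect can be drawn from the shown compounds. Compound 4 is therefore expected to give a number in the region of compound 1 and compound 2, the step of a 2.7-fold lower number from compound 3 to compound 4 (0.43 log units; beyond the scatter) being a modest fall, with compound 4 estimated at 7000 nM in this assay, between 2500 nM and 20000 nM.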

Compound 4, half-maximal inhibitory concentration: 8790 nM
Compound 4: the middle estimate sits 1.3-fold (0.10 log units) below what was measured; the range from low to high includes it.
By their numbers in this assay, from the lowest: compounds 1, 2 and 4 (each within the scatter of the next); then compound 3.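

On the aryl group held by the amide carbonyl carbon, 4-propylphenyl in place of 4-fluoro-3-methylphenyl gives a 2.2-fold lower number from compound 3 to compound 4 (0.33 log units; beyond the scatter), so a single alkyl chain at this position does not carry the rise seen with the combined fluoro and methyl substitution. Propyl in place of fluoro gives a 1.6-fold higher number from compound 1 to compound 4 (0.22 log units; within the scatter), and 4-propylphenyl in place of 3-methylphenyl gives a 1.3-fold higher number from compound 2 to compound 4 (0.12 log units; within the scatter), so in this assay the three singly substituted phenyl amides cannot be separated, and among the four compounds only compound 3 stands apart. Nothing shown here accounts for this outcome.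

From the compounds shown here alone, whether a longer chain such as butyl or hexyl would keep the number in this range remains open. So does the effect of an amine or a carboxylic acid on this phenyl ring.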